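The source may hold more compounds than are shown below. What is called first, only, known or untested is meant among the compounds shown, and "the series" means these compounds.

Measured compounds in an assay on CHO cells for displacement of a labelled ligand from Neuronal acetylcholine receptor; alpha3/alpha6/beta2/beta3 (Homo sapiens), read by scintillation counting; on this read-out lower numbers stand for stronger inhibition and higher numbers for weaker inhibition:
- compound 1, `O=C(C1CCC1)N1CC2CC(C1)N2`: 240 nM
- compound 2, `O=C(CC1C=CCC1)N1CC2CC(C1)N2`: 2500 nM
- compound 3, `O=C([C@H]1C[C@@H]1F)N1CC2CC(C1)N2`: 490 nM

Compound 1 stands at the lowest number of the three. Its nearest neighbour is compound 3, reached by a 2.0-fold higher number from compound 1 to compound 3 (0.31 log units; beyond the scatter). Within the data shown here, compound 2 lies much further off; no single-point step joins it to compound 1, so the two values are simply read side by side, with compound 2 giving 2500 nM against the figure of compound 1.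

Compound 4, `C[C@H]1C[C@H]1C(=O)N1CC2CC(C1)N2`, differs from compound 1 in one place: 2-methylcyclopropyl in place of cyclobutyl on a carbonyl carbon. Among the measured compounds shown here, the only measured step that bears on it is the one from compound 1 to compound 3, where a substituted cyclopropyl also replaced cyclobutyl on the carbonyl carbon and the number rose by a modest amount, beyond the scatter. The same kind of replacement here, with methyl rather than fluorine on the cyclopropyl, is expected to move the number in the same direction and by a similar, modest size; the expected step is a 1.6-fold higher number from compound 1 to compound 4 (0.20 log units; within the scatter). Compound 4 is therefore estimated at 380 nM in this assay, within an expected range from 160 nM to 900 nM.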

Compound 4, inhibition constant: 170 nM
Compound 4: middle estimate off by 2.2-fold (0.35 log units), on the high side, within the range that was stated.
By their numbers in this assay, from the lowest: compounds 4 and 1 (each within the scatter of the next); then compound 3; then compound 2.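

Notes on the group on the carbonyl carbon, in this assay: 2-methylcyclopropyl and cyclobutyl cannot be told apart here (a 1.4-fold lower number from compound 1 to compound 4 (0.15 log units; within the scatter)), so a three-membered ring at this position does not by itself carry the rise seen with compound 3. What separates the two cyclopropyl compounds is the substituent on the ring, methyl or fluorine (a 2.9-fold lower number from compound 3 to compound 4 (0.46 log units; beyond the scatter)), and this step lies beyond the scatter. No supporting data are available to explain either result.

Going by these compounds, whether unsubstituted cyclopropyl would sit with compound 1 and compound 4 or with compound 3 remains open, as does the reading of the other stereoisomers of 2-methylcyclopropyl. Also open, on these data alone, is how far the position tolerates larger or charged groups, such as an ethyl-substituted cyclopropyl or an amine on the ring.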